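Bromo to Fluoroformylphenyl: Cytotoxicity Outlook for Compound 4

This account rests on a few compounds, and the source may have more. Where it says the series, first, only, none or still open, it means among the compounds named here.

Compound 2 `Cc1c(Cc2ccc(Br)cc2)c(=O)oc2cc(OCC(O)CN3CCC(C(N)=O)CC3)ccc12` was examined in an ADME assay on A549 cells (Homo sapiens) for cytotoxicity, read by CellTiter-Glo; on this read-out higher numbers stand for lower toxicity in this test and lower numbers for higher toxicity in this test. In this assay compound 2 gives only a limit, > 100000 nM. Compound 1 `Cc1c(Cc2cccc(F)c2)c(=O)oc2cc(OCC(O)CN3CCC(C(N)=O)CC3)ccc12` gives 53300 nM in this assay. Compound 3 `Cc1cc(F)ccc1Cc1c(C)c2ccc(OCC(O)CN3CCC(C(N)=O)CC3)cc2oc1=O` also gives only a limit, > 100000 nM. The step of an at least 1.8-fold higher number from compound 1 to compound 2 (0.27 log units; that floor lies within the scatter) and the step of an at least 1.8-fold higher number from compound 1 to compound 3 (0.27 log units; that floor lies within the scatter) both sit at the floor of what the limit allows, and the step that the two limits leave unreadable from compound 2 to compound 3 cannot be read at all. This rests on (the limit of > 100000 nM in this assay, at which 2 of the 3 values shown sit).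

Compound 4 `Cc1c(Cc2ccc(-c3ccc(C=O)c(F)c3)cc2)c(=O)oc2cc(OCC(O)CN3CCC(C(N)=O)CC3)ccc12` differs from compound 2 in one place: 3-fluoro-4-formylphenyl in place of bromo on an aromatic carbon. None of the three measured steps concerns a change of this kind; all of them swap one small aryl for another on the saturated chain carbon, and none is resolved beyond the scatter. The record therefore offers no measured basis for a shift in either direction, and the expectation for compound 4 is a step of an at least 1.2-fold lower number from compound 2 to compound 4 (0.09 log units; that floor lies within the scatter) with a wide margin. Compound 4 is estimated at 80000 nM in this assay, between 20000 nM and 200000 nM, with a fair chance that only a limit is reported again.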

Compound 4, half-maximal cytotoxic concentration: 62400 nM
For compound 4 the middle estimate is 1.3-fold (0.11 log units) above the measured one, and the stated range covers the measured number.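

Within the data shown here, at this aromatic carbon, para to a large group, the earlier compounds offered no change at all; the swap to 3-fluoro-4-formylphenyl now gives in this assay an at least 1.6-fold lower number from compound 2 to compound 4 (0.20 log units; that floor lies within the scatter). The entering group adds a second aromatic ring of carbon only and a carbonyl, yet that floor does not separate the pair beyond the scatter, so no shift in toxicity can be claimed for this change. The value of compound 2, > 100000 nM, is a limit and not a number, and the true size of the step cannot be read: the limit of > 100000 nM in this assay, at which 2 of the 4 values shown sit.

From the compounds shown here alone, it remains open whether the formyl or the fluoro of the entering ring matters for this reading. Also open, going by these compounds, is how an unsubstituted phenyl, an amine or a carboxylic acid on this carbon would read.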